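Phenyl for thiophen-2-yl on a compound at the limit

A few compounds are considered here, and "the series" means these few. Any claim that something is new, unique, unknown or untested is made for them only; others in the source may bear on it.

Measured so far in a functional assay on K562 cells (Homo sapiens), read by MTT assay, with a stated time of 72 h; a lower number here means a stronger inhibitor, a higher number a weaker inhibitor
Compound 1 `COc1ncnc2c1c(-c1ccccc1)cn2[C@@H]1O[C@H](CO)[C@@H](O)[C@H]1O` - > 20000 nM (a limit)
Compound 2 `COc1nc(N)nc2c1c(-c1cccs1)cn2[C@@H]1O[C@H](CO)[C@@H](O)[C@H]1O` - > 20000 nM (a limit)

Neither compound has yielded a number in this assay. Compound 2 is reported only as a limit (> 20000 nM). The other compound shown is reported in the same way, so the two cannot be ranked against each other (the limit of > 20000 nM in this assay, at which 2 of the 2 values shown sit). The next compound to be tested is compound 3 `COc1nc(N)nc2c1c(-c1ccccc1)cn2[C@@H]1O[C@H](CO)[C@@H](O)[C@H]1O`. It has phenyl in place of thiophen-2-yl on an aromatic carbon, and the rest of compound 2 stays as it is (phenyl in place of thiophen-2-yl on an aromatic carbon). Going by the values given here, no measured pair of compounds shows what this exchange does, so the size of the step has to be judged from the limit alone. With compound 2 at its limit (> 20000 nM), no step beyond the scatter is expected in this assay, and another report of a limit is the likeliest outcome. The expected step, an estimate only, is (a number no higher from compound 2 to compound 3 (the limit leaves the size open)). For compound 3 the estimated value is (20000 nM), with an expected range from (8000 nM) to (40000 nM).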

Compound 3, half-maximal inhibitory concentration: > 20000 nM
Compound 3: only a limit was reported; the forecaster's own chance of this, stated with the estimate: 75%; the middle value lies on the limit itself.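

Compound 3 joins compound 1 and compound 2 as a limit in this assay, so neither the step from compound 2 to compound 3 nor the one from compound 1 to compound 3 can be read: the limit of > 20000 nM in this assay, at which 3 of the 3 values shown sit.

The compounds shown leave open whether phenyl in place of thiophen-2-yl, or amino in place of hydrogen, changes the read-out in this assay at all.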